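This account rests on a few compounds, and the source may have more. Where it says the series, first, only, none or still open, it means among the compounds named here.

In a functional assay on HCT-15 cells (Homo sapiens) for inhibition, read by sulforhodamine B assay (a lower number here means a stronger inhibitor of growth, a higher number a weaker inhibitor of growth), compound 1 `Nc1ccc(CNC(=O)CC2c3ccccc3N=C(N3CCCCC3)N2c2ccccc2)cc1` gives 33900 nM. Among the three compounds measured so far this number is the second highest: compound 2 `CCN1C(N2CCCCC2)=Nc2ccccc2C1CC(=O)NCc1ccccc1` gives 74200 nM, a value beyond the scatter above that of compound 1, while compound 3 `COC(=O)CC1c2ccccc2N=C(NCCCCCN)N1c1ccc(-c2ccccc2)cc1` gives 3640 nM, a value beyond the scatter below it. Compound 2 and compound 3 differ from compound 1 in more than one place, so no single change can be read from them.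

Compound 4 `Cc1ccc(S(=O)(=O)Nc2ccc(CNC(=O)CC3c4ccccc4N=C(N4CCCCC4)N3c3ccccc3)cc2)cc1` has not yet been measured in this assay. It differs from compound 1 in one place: (4-methylphenyl)sulfonyl in place of hydrogen on a nitrogen on an aromatic ring. Going by the values given here, no measured pair shows this particular change, so its effect on growth inhibition can only be guessed. The shared core stays unchanged, and the addition sits at the outer end of the molecule. On that basis the step from compound 1 to compound 4 is expected to be small, most likely a modest lowering of the number but possibly nothing beyond the scatter, as a 1.7-fold lower number from compound 1 to compound 4 (0.23 log units; within the scatter) states. Compound 4 is therefore estimated to give 20000 nM in this assay, with a likely range from 5000 nM to 80000 nM.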

Compound 4, concentration for 50% growth inhibition: 2800 nM
For compound 4 the middle estimate is 7.1-fold (0.85 log units) above the measured one, and the stated range ends above it.
By their numbers in this assay, from the lowest: compounds 4 and 3 (each within the scatter of the next); then compound 1; then compound 2.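

In this assay, putting (4-methylphenyl)sulfonyl in place of hydrogen on the nitrogen on an aromatic ring gives a 12-fold lower number from compound 1 to compound 4 (1.08 log units; beyond the scatter), a large step in the direction of stronger growth inhibition. The earlier compounds shown here each differ from compound 1 in more than one place, so they said nothing about this nitrogen; this single change shows that the outer end of the molecule is not indifferent to what is attached there, and that a substituent of this size on the amino group is compatible with a stronger inhibitor of growth. Nothing available bears on why the number falls this far.

Going by these compounds, a single step cannot separate the share of the sulfonyl link from that of the 4-methylphenyl ring, so it remains open whether a smaller methylsulfonyl, a plain phenylsulfonyl or an acetyl on the same nitrogen would go with a step of similar size. On these data alone, it is also open whether a chloro or methoxy group in place of the methyl on that ring would move the number further in either direction.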